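The source may hold more compounds than are shown below. What is called first, only, known or untested is meant among the compounds shown, and "the series" means these compounds.

Within the data shown here, compound 2, with structure `COc1ccccc1-n1nc([C@H]2C[C@@H](C)O[C@@H](C)C2)cc1-c1ccc(Cl)cc1`, gives 12 nM in an assay on HEK293 cells for inhibition of Voltage-dependent N-type calcium channel subunit alpha-1B (Homo sapiens), read by patch clamp, using a membrane potential dye (a lower number here means a stronger inhibitor, a higher number a weaker inhibitor), the lower of the two numbers measured so far. Compound 1, with structure `COc1ccccc1-n1nc(C2CC(C)(C)OC(C)(C)C2)cc1-c1ccnc(Cl)c1`, gives 250 nM in this assay, a gap beyond the scatter; the two differ in two places at once, so neither change can be weighed alone. Compound 3, with structure `COc1ccccc1-n1nc(C2CC(C)(C)OC(C)(C)C2)cc1-c1ccc(Cl)cc1`, carries 2,2,6,6-tetramethyloxan-4-yl in place of 2,6-dimethyloxan-4-yl on an aromatic carbon. Among the measured compounds shown here, no measured pair isolates this change. For compound 3 the expected step is a 3.3-fold higher number from compound 2 to compound 3 (0.52 log units; beyond the scatter), a modest move toward a higher number with wide uncertainty. Compound 3 is therefore estimated at 40 nM, within 10 nM to 160 nM.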

Compound 3, half-maximal inhibitory concentration: 16 nM
For compound 3 the middle estimate is 2.5-fold (0.40 log units) above the measured one; low and high end bracket the measured number.
By their numbers in this assay, from the lowest: compounds 2 and 3 (each within the scatter of the next); then compound 1.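

In this assay, the step of a 1.3-fold higher number from compound 2 to compound 3 (0.12 log units; within the scatter) shows that, on this aromatic carbon of the shared core, 2,2,6,6-tetramethyloxan-4-yl and 2,6-dimethyloxan-4-yl cannot be told apart. The step of a 16-fold lower number from compound 1 to compound 3 (1.19 log units; beyond the scatter) now isolates 4-chlorophenyl in place of 2-chloropyridin-4-yl as a large change, which the earlier pair could not separate from the change in the oxane ring. Nothing measured here explains either step. Still open, from the compounds shown here alone, is whether piperidin-4-yl, an amine ring, or plain cyclohexyl at this position would give a similar number.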